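This account rests on a few compounds, and the source may have more. Where it says the series, first, only, none or still open, it means among the compounds named here.

Among the measured compounds shown here, in a functional assay on MCF7 cells (Homo sapiens) for cytotoxicity, read by sulforhodamine B assay (a higher number here means a weaker inhibitor of growth, a lower number a stronger inhibitor of growth), compound 1 `CC1=CC[C@@H]([C@@](C)(O)CCCC(C)(C)NC(=S)N/N=C\c2ccc(O)cc2)CC1` gives 21200 nM, the only true number in this small series. Compound 2 `CC1=CC[C@@H]([C@@](C)(O)CCCC(C)(C)NC(=S)N/N=C\c2ccc(N(C)C)cc2)CC1` gives > 100000 nM, which is a limit of the assay and not a number. Compound 3 `CC1=CC[C@@H]([C@@](C)(O)CCCC(C)(C)NC(=S)N/N=C\c2ccccc2[N+](=O)[O-])CC1` gives > 100000 nM, which is also a limit and not a number. Compound 3 therefore has no exact place on the scale, and what stands out so far is the limit of > 100000 nM in this assay, at which 2 of the 3 values shown sit. As far as these compounds go, its comparison with its neighbour remains open: a step that the two limits leave unreadable from compound 2 to compound 3.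

Compound 4 `CC1=CC[C@@H]([C@@](C)(O)CCCC(C)(C)NC(=S)N/N=C\c2cccc(Cl)c2)CC1` has not been measured yet. It carries 3-chlorophenyl in place of 2-nitrophenyl on a carbon with a double bond to nitrogen. For the measured compounds named here, no measured step involves 3-chlorophenyl, so the guidance is indirect. The two readable steps both start from compound 1 and both run to weaker growth inhibition: an at least 4.7-fold higher number from compound 1 to compound 2 (0.67 log units; beyond the scatter) and an at least 4.7-fold higher number from compound 1 to compound 3 (0.67 log units; beyond the scatter). Compound 4 keeps no 4-hydroxyphenyl, so a return to the level of compound 1 seems possible but not likely. In this assay, a modest move toward a lower number is the most that can be expected. The expected change is an at least 1.6-fold lower number from compound 3 to compound 4 (0.22 log units; that floor lies within the scatter). The estimated value for compound 4 is 60000 nM, with an expected range from 20000 nM to 100000 nM.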

Compound 4, concentration for total growth inhibition: 19500 nM
For compound 4 the middle estimate is 3.1-fold (0.49 log units) above the measured one; the whole stated range lies above it.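

Among the compounds shown here, at this position, on a carbon with a double bond to nitrogen, the 4-hydroxyphenyl of compound 1 is not the only group compatible with measurable growth inhibition in this assay: 3-chlorophenyl in its place gives a 1.1-fold lower number from compound 1 to compound 4 (0.04 log units; within the scatter). The choice of aromatic group clearly matters among these compounds, since 3-chlorophenyl in place of 2-nitrophenyl gives an at least 5.1-fold lower number from compound 3 to compound 4 (0.70 log units; beyond the scatter), and 3-chlorophenyl in place of 4-(dimethylamino)phenyl gives an at least 5.1-fold lower number from compound 2 to compound 4 (0.70 log units; beyond the scatter). The true size of these last two steps cannot be read, because each starts from a limit of the assay and not from a number: the limit of > 100000 nM in this assay, at which 2 of the 4 values shown sit.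

The compounds shown do not tell whether the chlorine itself contributes, or whether it is enough for the ring to lack the nitro and dimethylamino groups. A plain phenyl group, or a methoxy group in place of the chlorine, would help separate these two readings in this assay.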